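Compound 3 to compound 4: butylamino for pentyloxy

A few compounds are considered here, and "the series" means these few. Any claim that something is new, unique, unknown or untested is made for them only; others in the source may bear on it.

Compound 1 (`Nc1nc(NC2CCCC2)c2ncn(/C=C3/CC3(CO)CO)c2n1`) gives > 20000 nM in an ADME assay on MOLT-3 cells (Homo sapiens) for cytotoxicity, with a stated time of 7 days (a lower number here means that less compound is tolerated, a higher number that more compound is tolerated), as a limit and not a number. Compound 2 (`CSc1nc(N)nc2c1ncn2/C=C1/CC1(CO)CO`) gives > 20000 nM in this assay as a limit too. Compound 3 (`CCCCCOc1nc(N)nc2c1ncn2/C=C1/CC1(CO)CO`) gives > 20000 nM as a limit as well, so it has no number of its own and stands level with the series at the limit of > 20000 nM in this assay, at which 3 of the 3 values shown sit, in every reading so far.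

The next structure is compound 4 (`CCCCNc1nc(N)nc2c1ncn2/C=C1/CC1(CO)CO`), with the change butylamino in place of pentyloxy on an aromatic carbon on an aromatic carbon. Among the measured compounds shown here, the steps that bear on it are a step that the two limits leave unreadable from compound 1 to compound 3 and a step that the two limits leave unreadable from compound 2 to compound 3 and a step that the two limits leave unreadable from compound 1 to compound 2 and none of them gives a size. The closest case is compound 1, with cyclopentylamino in place of pentyloxy, and its > 20000 nM is again a limit.

No step beyond the scatter is expected in this assay and no direction can be given. The expected change is a step that the limit leaves unreadable from compound 3 to compound 4 as an estimate only. Compound 4 is estimated at 25000 nM with an expected range from 12000 nM to 60000 nM and will probably be reported as a limit.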

Compound 4, half-maximal cytotoxic concentration: > 20000 nM
Compound 4 was reported as a limit; the forecaster's own chance of this, stated with the estimate: 85%; the middle value lies beyond the limit too.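

In this assay compound 4 is reported only as a limit, as are compounds 1, 2 and 3, so no new step between them can be read: the limit of > 20000 nM in this assay, at which 4 of the 4 values shown sit.

The compounds shown leave open how far any of these groups on the aromatic carbon shifts the cytotoxic concentration.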